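A few compounds are considered here, and "the series" means these few. Any claim that something is new, unique, unknown or untested is made for them only; others in the source may bear on it.

Measured so far:
- compound 1, `CCCn1c(=O)c(-c2cccc([N+](=O)[O-])c2)nc2ccccc21`, in an assay on cells for activation of Cystic fibrosis transmembrane conductance regulator (Homo sapiens), read by fluorescence, with a stated time of 10 min (on this read-out lower numbers stand for an effect already at smaller amounts and higher numbers for an effect only at larger amounts of compound), compound 1 gives 177 nM
- compound 2, `O=c1c(-c2cccc([N+](=O)[O-])c2)nc2ccccc2n1Cc1ccccn1`, in this assay compound 2 gives 52 nM

Compound 2 stands at the lowest of the two numbers; its nearest neighbour is compound 1, and the step of a 3.4-fold lower number from compound 1 to compound 2 (0.53 log units; beyond the scatter) lies beyond the scatter. For the measured compounds named here, that step exchanges ethyl for pyridin-2-yl on a saturated chain carbon bound to an aromatic nitrogen, and it is the only measured step.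

Compound 3, `O=c1c(-c2cccc([N+](=O)[O-])c2)nc2ccccc2n1Cc1cccs1`, has not been measured. It differs from compound 2 in one place: thiophen-2-yl in place of pyridin-2-yl on a saturated chain carbon bound to an aromatic nitrogen. Going by the values given here, the measured step from compound 1 to compound 2 bears on this only loosely, as it shows that an aromatic ring at this place is compatible with a low number; no measured pair compares two different aromatic rings there. A thiophen-2-yl ring in place of pyridin-2-yl keeps an aromatic ring at the same place, so compound 3 is expected to remain near compound 2, with a step of a 1.3-fold higher number from compound 2 to compound 3 (0.13 log units; within the scatter) that stays within or just at the scatter. The estimate for compound 3 in this assay is therefore 70 nM, with a range from 25 nM to 200 nM.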

Compound 3, half-maximal effective concentration: 10 nM
Beside the measured number, compound 3's estimate is 7.0-fold (0.85 log units) above it; measured number below the stated range.
By their numbers in this assay, from the lowest: compound 3; then compound 2; then compound 1.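

In this assay the exchange of pyridin-2-yl for thiophen-2-yl on a saturated chain carbon bound to an aromatic nitrogen gives a clear change (a 5.2-fold lower number from compound 2 to compound 3 (0.72 log units; beyond the scatter)), so this place does not merely tolerate an aromatic ring but separates one aromatic ring from another. Measured against ethyl, thiophen-2-yl gives the largest step in the series (an 18-fold lower number from compound 1 to compound 3 (1.25 log units; beyond the scatter)), which shows that the identity of the ring matters here as well as its presence. No measurement of any property of these groups is available to account for the difference between the two rings.

The compounds shown leave open whether phenyl or furan-2-yl at this place would give a number closer to that of thiophen-2-yl or to that of pyridin-2-yl, and whether the low number would survive a longer chain between the ring and the aromatic nitrogen. They also leave open whether thiophen-2-yl would keep its advantage over pyridin-2-yl if the nitro group were replaced by a nitrile or an amine.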